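Benzoyl to (4-methylphenyl)carbonyl on compound 1

The compounds below may be only part of what the source reports. "The series", "measured", "known", "first", "only" and "open" are said of these compounds alone.

Among the measured compounds shown here, in a functional assay on G55T2 cells (Homo sapiens) for antiproliferative activity, read by WST assay, with a stated time of 72 h (a lower number here means a stronger inhibitor, a higher number a weaker inhibitor), compound 1 `O=C(CCN(Cc1ccc(C(=O)NO)cc1)C(=O)c1ccccc1)NCc1ccccc1` gives 5940 nM, the higher of the two numbers so far, and compound 2 `Cc1ccc(NC(=O)CCN(Cc2ccc(C(=O)NO)cc2)C(=O)c2ccccc2)cc1` gives 540 nM. That measured step, an 11-fold lower number from compound 1 to compound 2 (1.04 log units; beyond the scatter), puts 4-methylphenyl in place of benzyl on an amide-type nitrogen. Compound 3 `Cc1ccc(C(=O)N(CCC(=O)NCc2ccccc2)Cc2ccc(C(=O)NO)cc2)cc1` keeps that benzyl and instead has methyl in place of hydrogen on an aromatic carbon, para to a large group (methyl in place of hydrogen on an aromatic carbon). The measured step lies elsewhere in the molecule, so it says little about this change. In this assay, no step beyond the scatter is therefore expected, and the estimate is a 1.3-fold lower number from compound 1 to compound 3 (0.12 log units; within the scatter). Compound 3 is expected at 4500 nM, within a range of 1800 nM to 9500 nM.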

Compound 3, half-maximal inhibitory concentration: 690 nM
For compound 3 the middle estimate is 6.5-fold (0.81 log units) above the measured one, outside the stated range (below it).
By their numbers in this assay, from the lowest: compounds 2 and 3 (each within the scatter of the next); then compound 1.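

A single methyl on this aromatic carbon, para to a large group, gives an 8.6-fold lower number from compound 1 to compound 3 (0.93 log units; beyond the scatter). The benzoyl end of compound 1 therefore responds to a very small addition, a point the earlier step, made at the benzyl end, could not show. No measurement offered here explains this gain. As far as these compounds go, whether ethyl, a chlorine atom or a methoxy group on this carbon would act like methyl remains open. So does whether this methyl and the 4-methylphenyl of compound 2 would add up in one molecule.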